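Amide substituent swap on the spirocyclic core toward an ethylpiperidine

The source may report more compounds than this note shows. Statements on the series, on what has been measured and on what is new or still open speak of the compounds shown alone.

Measured compounds:
compound 1 `CC(C)(C)c1ccc(C(=O)N2CCC3(CC2)C(=O)N(CC(=O)N2CCC(CCO)CC2)CN3c2ccccc2)cc1`: 2600 nM
compound 2 `CC(C)(C)OC(=O)NCCCNC(=O)CN1CN(c2ccccc2)C2(CCN(C(=O)c3ccc(C(C)(C)C)cc3)CC2)C1=O`: 4500 nM
compound 3 `CC(C)(C)c1ccc(C(=O)N2CCC3(CC2)C(=O)N(CC(=O)N2CCCCC2CO)CN3c2ccccc2)cc1`: 11800 nM

In an assay on HEK293 cells for displacement of a labelled ligand from NPC1-like intracellular cholesterol transporter 1 (Homo sapiens) (a lower number here means a stronger inhibitor, a higher number a weaker inhibitor), compound 3 gives the highest number of the three. Its nearest neighbour is compound 2, and the step of a 2.6-fold higher number from compound 2 to compound 3 (0.42 log units; beyond the scatter) lies beyond the scatter; the step of a 4.5-fold higher number from compound 1 to compound 3 (0.66 log units; beyond the scatter) is larger still. The step of a 1.7-fold higher number from compound 1 to compound 2 (0.24 log units; within the scatter) is within the scatter.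

Compound 4 `CCC1CCCN(C(=O)CN2CN(c3ccccc3)C3(CCN(C(=O)c4ccc(C(C)(C)C)cc4)CC3)C2=O)C1` differs from compound 3 at the same carbonyl carbon that separates all three measured compounds: 3-ethylpiperidin-1-yl in place of 2-(hydroxymethyl)piperidin-1-yl on a carbonyl carbon. Both measured steps that reach compound 3 replace the group on this carbonyl carbon, and both lowered the number when the 2-(hydroxymethyl)piperidin-1-yl group was absent. Going by the values given here, no measured pair shows the 3-ethylpiperidin-1-yl group, so the direction rests on those two steps only. Compound 4 is therefore expected to give a modestly lower number than compound 3, the step of a 2.0-fold lower number from compound 3 to compound 4 (0.29 log units; within the scatter) being the estimate, with wide uncertainty. Compound 4 is estimated at 6000 nM, between 2000 nM and 20000 nM.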

Compound 4, half-maximal inhibitory concentration: 3900 nM
The estimate for compound 4 lay 1.5-fold (0.19 log units) above the measured number; low and high end bracket the measured number.
By their numbers in this assay, from the lowest: compounds 1, 4 and 2 (each within the scatter of the next); then compound 3.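

In this assay, the 3-ethylpiperidin-1-yl group, with 0 hydrogen-bond donors and 0 hydrogen-bond acceptors, shows that a piperidine on this carbonyl carbon needs no hydroxyl group to match compound 1: there is a 1.5-fold higher number from compound 1 to compound 4 (0.18 log units; within the scatter), and also a 1.2-fold lower number from compound 2 to compound 4 (0.06 log units; within the scatter). The change from the 2-(hydroxymethyl)piperidin-1-yl group gives a 3.0-fold lower number from compound 3 to compound 4 (0.48 log units; beyond the scatter), so among these compounds only compound 3 stands apart, yet this step alters both the substituent and its place on the ring. No evidence is available to explain the difference.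

The compounds shown leave open whether the place on the ring or the hydroxymethyl group itself separates compound 3 from compound 4. A 2-ethylpiperidin-1-yl or a 3-(hydroxymethyl)piperidin-1-yl group at this carbonyl carbon would divide the two changes.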